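Amide series: cytotoxicity readings and a bromophenyl analogue

This account rests on a few compounds, and the source may have more. Where it says the series, first, only, none or still open, it means among the compounds named here.

The set to date comprises compound 1 `COc1ccccc1NC(=O)c1ccc2cccc(O)c2n1` and compound 2 `O=C(Nc1cccc(F)c1)c1ccc2cccc(O)c2n1`, both tested in an ADME assay on THP-1 cells (Homo sapiens) for cytotoxicity, read by WST assay, with a stated time of 24 h; on this read-out higher numbers stand for weaker inhibition and lower numbers for stronger inhibition. Compound 1 reaches only a limit in this assay, giving > 30000 nM. Compound 2 likewise returns a limit rather than a number, > 30000 nM. For the measured compounds named here, compound 2 therefore stands at the ceiling of the read-out alongside the other measured compound; with the limit of > 30000 nM in this assay, at which 2 of the 2 values shown sit, no step between measured compounds can be stated, and the two values show nothing beyond the shared limit.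

The next compound is compound 3 `O=C(Nc1ccccc1Br)c1ccc2cccc(O)c2n1`, which differs from compound 2 in one place: 2-bromophenyl in place of 3-fluorophenyl on an amide-type nitrogen. Going by the values given here, no measured step in this assay bears on an exchange of this kind, and the series offers no value below the limit from which a direction could be read. The expected step is a number no higher from compound 2 to compound 3 (the limit leaves the size open), that is, none beyond the scatter, with the result most likely again reported as a limit. Compound 3 is expected to give about 30000 nM in this assay, with a range of 10000 nM to 100000 nM.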

Compound 3, half-maximal inhibitory concentration: > 30000 nM
Compound 3 gave a limit, no number; the forecaster's own chance of this, stated with the estimate: 80%; the middle value sits exactly at the limit.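

In this assay compound 3 gives > 30000 nM, a limit and not a number. No step from compound 1 or compound 2 to compound 3 can be read: the limit of > 30000 nM in this assay, at which 3 of the 3 values shown sit.

The compounds shown leave open whether any exchange on the amide-type nitrogen brings a value under the limit in this assay.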